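Swapping the aryl group on an enone sulfide

A few compounds are considered here, and "the series" means these few. Any claim that something is new, unique, unknown or untested is made for them only; others in the source may bear on it.

Compound 1 `Cc1ccc(S/C(=C/c2ccc(Cl)c(Cl)c2)C(=O)c2ccc(Br)cc2)cc1` is a thioenone bearing a 3,4-dichlorophenyl group. In a functional assay on DU-145 cells (Homo sapiens) for inhibition, read by trypan blue exclusion, with a stated time of 96 h (a higher number here means a weaker inhibitor of growth, a lower number a stronger inhibitor of growth), compound 1 gives 50000 nM, the highest of the two numbers recorded. Going by the values given here, compound 2 `O=C(/C(=C\c1ccc([N+](=O)[O-])c(O)c1)SCc1ccc(Br)cc1)c1cc(Cl)ccc1O` is the only comparison; in this assay compound 2 gives 10000 nM, a lower number than compound 1, and the gap between them is beyond the scatter. Among the compounds with values here, the two differ at several places, so no single step can be traced between them.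

Compound 3 `CC(=O)c1ccc(/C=C(/Sc2ccc(C)cc2)C(=O)c2ccc(Br)cc2)cc1` has not yet been measured. It differs from compound 1 by 4-acetylphenyl in place of 3,4-dichlorophenyl on a double-bonded chain carbon bound to a double-bonded chain carbon. Nothing measured bears on this particular exchange, so there is no basis for expecting a shift in either direction. The step expected from this change is no change at the digits printed from compound 1 to compound 3 (within the scatter), none beyond the scatter. Compound 3 is therefore estimated at 50000 nM, with a range from 15000 nM to 150000 nM.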

Compound 3, concentration for 50% growth inhibition: 50000 nM
Compound 3: the middle estimate sits on the measured number at the digits printed, within the range that was stated.
By their numbers in this assay, from the lowest: compound 2; then compounds 1 and 3 (each within the scatter of the next).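

In this assay, going by these compounds alone, 4-acetylphenyl in place of 3,4-dichlorophenyl on a double-bonded chain carbon bound to a double-bonded chain carbon gives no change at the digits printed from compound 1 to compound 3 (within the scatter) in the only single-place step available so far. The earlier compounds shown here could not show this: the position now accepts an aryl group that carries a carbonyl and no chlorine without a shift beyond the scatter, at least on the core of compound 1. No measurement offered here accounts for this outcome. The compounds shown leave open whether an amine or a carboxylic acid on the same ring would move the number. They also leave open whether the same exchange would give the same step on a core with a different sulfur substituent.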